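Dimethylamino to chloro on the aromatic ring

This account rests on a few compounds, and the source may have more. Where it says the series, first, only, none or still open, it means among the compounds named here.

For the measured compounds named here, in a functional assay on MCF7 cells (Homo sapiens) for cytotoxicity, read by sulforhodamine B assay (on this read-out lower numbers stand for stronger inhibition of growth and higher numbers for weaker inhibition of growth), compound 1 `CC1=CC[C@@H]([C@@](C)(O)CCCC(C)(C)NC(=S)N/N=C\c2ccc(N(C)C)cc2)CC1` gives 14000 nM, the lower of the two numbers so far, and compound 2 `CC1=CC[C@@H]([C@@](C)(O)CCCC(C)(C)NC(=S)N/N=C\c2ccccc2Cl)CC1` gives 31200 nM. Compound 3 `CC1=CC[C@@H]([C@@](C)(O)CCCC(C)(C)NC(=S)N/N=C\c2ccc(Cl)cc2)CC1` is not yet measured and differs from compound 1 by chloro in place of dimethylamino on an aromatic carbon, with chloro in place of dimethylamino on an aromatic carbon. Going by the values given here, the one measured step bearing on this, a 2.2-fold higher number from compound 1 to compound 2 (0.35 log units; beyond the scatter), is modest and also removes 4-(dimethylamino)phenyl, though it brings in 2-chlorophenyl rather than 4-chlorophenyl. A step of similar size towards weaker growth inhibition is expected, a 1.9-fold higher number from compound 1 to compound 3 (0.27 log units; within the scatter). For compound 3 the estimate is 26000 nM, with an expected range of 12000 nM to 55000 nM.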

Compound 3, concentration for 50% growth inhibition: 6890 nM
Estimate against measurement, compound 3: 3.8-fold (0.58 log units) above; measured number below the stated range.
By their numbers in this assay, from the lowest: compound 3; then compound 1; then compound 2.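

In this assay, chloro in place of dimethylamino on this aromatic carbon gives a change towards stronger growth inhibition (a 2.0-fold lower number from compound 1 to compound 3 (0.31 log units; beyond the scatter)), so losing 4-(dimethylamino)phenyl does not itself weaken growth inhibition. The placement of the chloro matters more, with 4-chlorophenyl in place of 2-chlorophenyl giving the larger step (a 4.5-fold lower number from compound 2 to compound 3 (0.66 log units; beyond the scatter)) and leaving compound 3 with the lowest number of the three. Nothing measured here accounts for either step.

From the compounds shown here alone, whether bromo, methoxy or a carboxylic acid at this place would follow chloro or dimethylamino remains open.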